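Changing the Aryl Group on the Carbonyl: Three Measured, One Expected

This account rests on a few compounds, and the source may have more. Where it says the series, first, only, none or still open, it means among the compounds named here.

Compound 1 `COc1cc(-c2cc(/C=C/C(=O)c3ccc(N)cc3)[nH]n2)cc(OC)c1OC`: 95%
Compound 2 `COc1cc(-c2cc(/C=C/C(=O)c3ccc(Cl)c(Cl)c3)[nH]n2)cc(OC)c1OC`: 89%
Compound 3 `COc1ccc(C(=O)/C=C/c2cc(-c3cc(OC)c(OC)c(OC)c3)n[nH]2)cc1`: 92%

Three compounds were measured in a functional assay on NCI-H322M cells (Homo sapiens) for cytotoxicity, read by sulforhodamine B assay, with a stated time of 48 h, tested at 0.01 uM; a lower number here means a stronger effect, a higher number a weaker effect of the compound at the concentration tested. Compound 3 stands second highest of the three, and the steps of a number 3 percentage points lower from compound 1 to compound 3 (within the scatter) and a number 3 percentage points higher from compound 2 to compound 3 (within the scatter) both lie within the scatter, so the three values cannot be told apart.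

Compound 4 `COc1cc(-c2cc(/C=C/C(=O)c3ccc(F)c(F)c3)[nH]n2)cc(OC)c1OC` has not yet been measured. It differs from compound 3 by 3,4-difluorophenyl in place of 4-methoxyphenyl on a carbonyl carbon. Among the measured compounds shown here, the steps that bear on this are the two earlier changes at the carbonyl carbon, a number 6 percentage points lower from compound 1 to compound 2 (within the scatter) and a number 3 percentage points higher from compound 2 to compound 3 (within the scatter), both within the scatter. No step beyond the scatter is therefore expected in this assay. Compound 4 is expected to give 91%, within 82% to 99%. The expected step is a number 1 percentage points lower from compound 3 to compound 4 (within the scatter).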

Compound 4, a percentage reported as activity, at one concentration (the size of the read-out at that concentration, not a potency): 94%
Compound 4: middle estimate off by 3 percentage points, on the low side; the measured number falls inside the stated range.
By their numbers in this assay, from the lowest: compounds 2, 3, 4 and 1 (each within the scatter of the next).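

In this assay the change to 3,4-difluorophenyl on the carbonyl carbon gives a number 2 percentage points higher from compound 3 to compound 4 (within the scatter) and a number 5 percentage points higher from compound 2 to compound 4 (within the scatter) and a number 1 percentage points lower from compound 1 to compound 4 (within the scatter) so all three new steps stay small. A fourth aryl group at this position therefore joins the other three, and the four values cannot be told apart. Nothing at hand offers a reason for this.

As far as these compounds go, whether a carboxylic acid on the aryl ring, or a longer chain in place of that ring, would give a step beyond the scatter stays open. So does how these compounds compare at higher concentrations.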